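The compounds below may be only part of what the source reports. "The series", "measured", "known", "first", "only" and "open" are said of these compounds alone.

Compound 1, `COc1cc(-c2cc(/C=C/C(=O)c3ccc(N)cc3)[nH]n2)cc(OC)c1OC`: 4840 nM
Compound 2, `COc1ccc(-c2cc(/C=C/C(=O)c3ccc(OC)c(OC)c3)[nH]n2)cc1`: 2110 nM

In a functional assay on TK-10 cells (Homo sapiens) for inhibition, read by sulforhodamine B assay, with a stated time of 48 h (a higher number here means a weaker inhibitor of growth, a lower number a stronger inhibitor of growth), compound 1 gives 4840 nM and compound 2 gives 2110 nM. Of these two numbers, compound 1 has the higher one, so it is the weaker growth inhibitor of the pair, and its gap to compound 2 lies beyond the usual scatter of this measurement. Compound 3, `COc1cc(-c2cc(/C=C/C(=O)c3ccc(Cl)c(Cl)c3)[nH]n2)cc(OC)c1OC`, has not yet been measured in this assay. It differs from compound 1 in a single place: 3,4-dichlorophenyl in place of 4-aminophenyl on a carbonyl carbon. Among the compounds with values here, compound 1 and compound 2 differ from each other at several positions, so no step between measured compounds shows what this one swap does on its own. With nothing measured on this exact change, compound 3 is expected to land near compound 1, shifted modestly toward stronger inhibition, as the step of a 1.6-fold lower number from compound 1 to compound 3 (0.21 log units; within the scatter) describes. The estimate for compound 3 is 3000 nM, with a range from 1000 nM to 9000 nM.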

Compound 3, concentration for 50% growth inhibition: 8340 nM
Estimate against measurement, compound 3: 2.8-fold (0.44 log units) below; the measured number falls inside the stated range.
By their numbers in this assay, from the lowest: compound 2; then compounds 1 and 3 (each within the scatter of the next).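

In this assay, this position now has a direct comparison, and replacing 4-aminophenyl with 3,4-dichlorophenyl on the carbonyl carbon gives a 1.7-fold higher number from compound 1 to compound 3 (0.24 log units; within the scatter). The swap removes the hydrogen-bond donor and acceptor counted on 4-aminophenyl and brings in two chlorine atoms, yet this measurement does not separate the two compounds. No measurement at hand accounts for this result.

On these data alone, it remains open whether a phenyl ring carrying a carboxylic acid, or a single fluorine atom, would shift the number beyond the scatter at this position. Compound 2 differs from compound 1 at several positions, so it cannot show what this position contributes.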